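Shortening the Nitrogen Chain in an Inactive Series

The source may hold more compounds than are shown below. What is called first, only, known or untested is meant among the compounds shown, and "the series" means these compounds.

Compound 1 `CCCCn1nc(Cc2ccc(SC)cc2)c2ccccc2c1=O` gives > 100000 nM in a functional assay on aorta with Alpha-1D adrenergic receptor (Rattus norvegicus) as the target (on this read-out lower numbers stand for an effect already at smaller amounts and higher numbers for an effect only at larger amounts of compound), a limit of the assay.
Compound 2 `CCCCn1nc(Cc2ccc(Cl)cc2)c2ccccc2c1=O` gives > 100000 nM in this assay, again a limit.
Compound 3 `COc1ccc(Cc2nn(-c3ccc(Br)cc3)c(=O)c3ccccc23)cc1OC` gives > 100000 nM in this assay, also a limit.

On the numbers shown, compound 1 stands only at a limit, and the two further values shown are limits as well (the limit of > 100000 nM in this assay, at which 3 of the 3 values shown sit). The step from compound 1 to compound 2, a step that the two limits leave unreadable from compound 1 to compound 2, is chloro in place of methylsulfanyl on an aromatic carbon; its size is not readable, with both ends at the limit. Going by the values given here, for compound 3 no step to compound 1 is given, and its value, too, is a limit.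

Compound 4 `CSc1ccc(Cc2nn(C)c(=O)c3ccccc23)cc1` differs from compound 1 by hydrogen in place of propyl on a saturated chain carbon bound to an aromatic nitrogen; cut one bond further out, the same difference reads butyl to methyl. Among the compounds with values here, none of the measured steps touches this place: the one measured pair differs on the aromatic carbon, and its size cannot be read. Within the data shown here, no measured step therefore bears on the change, and in this assay no step beyond the scatter can be predicted in either direction. The estimate is that compound 4 remains at the limit, so the step that the limit leaves unreadable from compound 1 to compound 4 is expected to be small. Compound 4 is expected at 150000 nM, in a range from 30000 nM to 1000000 nM.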

Compound 4, half-maximal effective concentration: 930 nM
Estimate against measurement, compound 4: 160-fold (2.21 log units) above; measured number below the stated range.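

Hydrogen in place of propyl on a saturated chain carbon bound to an aromatic nitrogen, which reads butyl to methyl when cut one bond further out, gives an at least 100-fold lower number from compound 1 to compound 4 (2.03 log units; beyond the scatter) in this assay, so this place on the shared core has a large bearing on the read-out. Going by these compounds alone, compound 1 stands at a limit, which makes this step a minimum size and not an exact one, yet it is the first readable difference in the set, and it comes from the chain on the nitrogen and not from the aromatic carbon changed in the earlier pair. Before compound 4, no change could be sized at all: the limit of > 100000 nM in this assay, at which 3 of the 4 values shown sit.

From the compounds shown here alone, whether the lower number belongs to methyl alone, or would hold with an ethyl or propyl chain on this nitrogen, or with an amine or a hydroxyl at the end of a longer chain, stays open. Going by these compounds, the step from methylsulfanyl to chloro cannot be read between its two limits, so it also stays open whether chloro in place of methylsulfanyl would shift the number once the chain is methyl.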